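Dichlorophenyl Swap in a Cytotoxicity Series: Working Notes

This account rests on a few compounds, and the source may have more. Where it says the series, first, only, none or still open, it means among the compounds named here.

Compound 1 `COc1cccc(/C=C2\CCC/C(=C\c3ccc(Cl)c(Cl)c3)C2=O)c1OC` sits at a limit in a functional assay on A549 cells (Homo sapiens) for cytotoxicity, read by MTT assay, with a stated time of 72 h (a lower number here means a stronger inhibitor, a higher number a weaker inhibitor), reported as > 20000 nM; this is the limit of > 20000 nM in this assay, at which 1 of the 3 values shown sits, and not a number. Compound 2 `COc1cccc(/C=C2\CCC/C(=C\c3cc(Cl)cc(Cl)c3)C2=O)c1OC` gives 12500 nM in this assay. Compound 3 `COc1ccc(/C=C2\CCC/C(=C\c3ccc(Cl)c(Cl)c3)C2=O)cc1OC` gives 6900 nM; its value and that of compound 2 lie within the scatter of each other. The difference between the cores of compound 1 and compound 3 is not broken down here.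

From compound 1 to compound 2 the change is 3,5-dichlorophenyl in place of 3,4-dichlorophenyl on a double-bonded chain carbon bound to a double-bonded ring carbon, and it made an at least 1.6-fold lower number from compound 1 to compound 2 (0.20 log units; that floor lies within the scatter). Compound 4 `COc1ccc(/C=C2\CCC/C(=C\c3cc(Cl)cc(Cl)c3)C2=O)cc1OC` is not yet measured; it differs from compound 3 by 3,5-dichlorophenyl in place of 3,4-dichlorophenyl on a double-bonded chain carbon bound to a double-bonded ring carbon, the same change at the same place.

A step of about a 1.5-fold lower number from compound 3 to compound 4 (0.19 log units; within the scatter) is expected from compound 3 to compound 4, resting on the measured at least 1.6-fold lower number from compound 1 to compound 2 (0.20 log units; that floor lies within the scatter). Compound 4 is estimated at 4500 nM, expected between 2000 nM and 12000 nM.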

Compound 4, half-maximal inhibitory concentration: 5500 nM
Estimate against measurement, compound 4: 1.2-fold (0.09 log units) below, within the range that was stated.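

In this assay the swap to 3,5-dichlorophenyl gives a 1.3-fold lower number from compound 3 to compound 4 (0.10 log units; within the scatter), so on this core the change has no effect that can be told from the scatter. Set beside the other core, the two steps cannot be separated: the same change on two cores in this assay, an at least 1.6-fold lower number (0.20 log units; that floor lies within the scatter) from compound 1 to compound 2 and a 1.3-fold lower number (0.10 log units; within the scatter) from compound 3 to compound 4; the limit leaves it open whether they differ. Compound 1 stands at a limit, > 20000 nM, which is not a number, so its step has only a floor, and the pair shows no real effect carried from one core to the other.

Going by these compounds, whether any chlorine placement matters in this assay remains open. Also open, on these data alone, is how an amine or a carboxylic acid on this ring would read in place of the two chlorines.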